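The source may hold more compounds than are shown below. What is called first, only, known or untested is meant among the compounds shown, and "the series" means these compounds.

Measured compounds:
compound 1 `OC[C@H]1O[C@@H](n2cnc3c(NCc4ccc(Cl)cc4Cl)ncnc32)[C@H](O)[C@@H]1O`: 128000 nM
compound 2 `OC[C@H]1O[C@@H](n2cnc3c(NCc4cc(F)cc(F)c4)ncnc32)C(O)C1O`: > 166000 nM

Both results come from a functional assay on G-361 cells (Homo sapiens) for antiproliferative activity, with a stated time of 72 h; a higher number here means a weaker inhibitor, a lower number a stronger inhibitor. Among the measured compounds shown here, compound 1 stands as the only compound of the pair with a numerical result in this assay, and that number places it at the weak end of what the assay resolves. Compound 2 returns only a limit of the assay, not a number, as recorded in the limit of > 166000 nM in this assay, at which 1 of the 2 values shown sits. For the measured compounds named here, with one number and one limit, no step between measured compounds can be drawn, so the pair gives no direct precedent for the change considered next.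

Compound 3 `OC[C@H]1O[C@@H](n2cnc3c(NCc4ccc(C(F)(F)F)cc4)ncnc32)[C@H](O)[C@@H]1O` is the unmeasured member. It differs from compound 1 in one place: 4-(trifluoromethyl)phenyl in place of 2,4-dichlorophenyl on a saturated chain carbon bound to a nitrogen on an aromatic ring. Going by the values given here, no measured step covers this kind of exchange, so the expectation rests on the position of compound 1 alone. The step from compound 1 to compound 3 in this assay is expected to stay within the usual scatter, in either direction, with a fair chance that compound 3 itself only reaches the limit of the assay. Compound 3 is accordingly estimated at 150000 nM, between 60000 nM and 330000 nM, which corresponds to a 1.2-fold higher number from compound 1 to compound 3 (0.07 log units; within the scatter).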

Compound 3, half-maximal inhibitory concentration: > 166000 nM
Compound 3: only a limit was reported; the forecaster's own chance of this, stated with the estimate: 45%; at least 1.1-fold (0.04 log units) between middle value and limit.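

Compound 3 gives only a limit of the assay, > 166000 nM, in this assay. Among the compounds shown here, this provides the first readable step at this position: exchanging 2,4-dichlorophenyl for 4-(trifluoromethyl)phenyl on a saturated chain carbon bound to a nitrogen on an aromatic ring gives an at least 1.2-fold higher number from compound 1 to compound 3 (0.11 log units; that floor lies within the scatter), so the step has a floor but no upper bound, and the floor alone does not establish a real loss. Compound 1 remains the only compound of the three with a number in this assay, and the other two results now share one limit: the limit of > 166000 nM in this assay, at which 2 of the 3 values shown sit.

Going by these compounds, how far the true value of compound 3 lies past its limit remains open, and with it the real size of this exchange, which could be small or large. Also open, on these data alone, is whether a phenyl group carrying an amine or a carboxylic acid, or a longer chain at this place, would bring the series to a number clearly stronger than that of compound 1, rather than leaving it at the limit.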